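Moving the chlorine on a cinnamamide aryl ring

The compounds below may be only part of what the source reports. "The series", "measured", "known", "first", "only" and "open" are said of these compounds alone.

Compound 1, `CCCc1cc(N)c2cc(NC(=O)/C=C/c3ccc(CC)cc3)ccc2n1`: in an assay on isolated protein for displacement of a labelled ligand from melanin-concentrating hormone receptor 1 (Homo sapiens) (on this read-out lower numbers stand for stronger inhibition and higher numbers for weaker inhibition), compound 1 gives 1.4 nM.
Compound 2, `CCCc1cc(N)c2cc(NC(=O)/C=C/c3ccc(C(C)C)cc3)ccc2n1`: compound 2 gives 2.9 nM.
Compound 3, `CCCc1cc(N)c2cc(NC(=O)/C=C/c3ccccc3Cl)ccc2n1`: compound 3 gives 120 nM.

Compound 3 stands highest of the three numbers, separated from compound 2 by a 41-fold higher number from compound 2 to compound 3 (1.62 log units; beyond the scatter) and from compound 1 by an 86-fold higher number from compound 1 to compound 3 (1.93 log units; beyond the scatter). Compound 4, `CCCc1cc(N)c2cc(NC(=O)/C=C/c3cccc(Cl)c3)ccc2n1`, has not been measured. It differs from compound 3 by 3-chlorophenyl in place of 2-chlorophenyl on a double-bonded chain carbon bound to a double-bonded chain carbon; the two compounds share all atoms and differ only in where the chlorine sits on the ring.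

Both measured steps that lead to compound 3 are large, yet each replaces a 4-alkylphenyl with 2-chlorophenyl, so neither compares two chlorophenyl placements directly. Among the compounds with values here, the only smaller step in the set, a 2.1-fold higher number from compound 1 to compound 2 (0.32 log units; beyond the scatter), concerns the alkyl group and does not bear on the present change. The data therefore leave the direction open; the large loss on reaching compound 3 is expected to be partly recovered, with wide uncertainty. Compound 4 is estimated at 25 nM, within 5 nM to 120 nM. This estimate amounts to an expected 4.8-fold lower number from compound 3 to compound 4 (0.68 log units; beyond the scatter).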

Compound 4, half-maximal inhibitory concentration: 1100 nM
Beside the measured number, compound 4's estimate is 44-fold (1.64 log units) below it; the whole stated range lies below it.
By their numbers in this assay, from the lowest: compound 1; then compound 2; then compound 3; then compound 4.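

With the atoms unchanged, moving the chlorine alone shifts the result in this assay (a 9.2-fold higher number from compound 3 to compound 4 (0.96 log units; beyond the scatter)), so placement on this ring matters independently of which atoms are present, and 3-chlorophenyl gives weaker inhibition than 2-chlorophenyl. The distance from the 4-alkylphenyl compounds grows accordingly (a 380-fold higher number from compound 2 to compound 4 (2.58 log units; beyond the scatter); a 790-fold higher number from compound 1 to compound 4 (2.90 log units; beyond the scatter)), leaving compound 4 the weakest of the four. No measurement shown here accounts for the difference between the two chlorine placements.

The compounds shown leave open whether a bromine or a methoxy group in place of the chlorine would keep the same order between the two ring placements. They also leave open whether an ethyl or isopropyl group, moved as the chlorine was, would show a comparable loss.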